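This account rests on a few compounds, and the source may have more. Where it says the series, first, only, none or still open, it means among the compounds named here.

For the measured compounds named here, in a physicochemical assay for acid dissociation, compound 1 `CCCn1c(=O)c2nc(-c3ccccc3N)[nH]c2n(CCC)c1=O` gives 9.1, the only single number available, while compound 2 `CCn1c(=O)c2nc(-c3ccc(S(=O)(=O)NCCN(C)C)cc3)[nH]c2n(CC)c1=O` has two entries, 6.8; 8 (2 entries). Compound 3 `CCCn1c(=O)c2nc(-c3ccc(Cl)cc3N)[nH]c2n(CCC)c1=O` keeps the core of compound 1 and differs from it in one place: chloro in place of hydrogen on an aromatic carbon, meta to an amino group and para to a large group. Going by the values given here, no measured pair shows this change, so only a small downward step is expected in this assay, close to the scatter. The estimated step is a number 0.20 log units lower from compound 1 to compound 3 (within the scatter). Compound 3 is expected at 8.9, with a range of 8.5 to 9.2.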

Compound 3, acid dissociation constant: 8.4
Compound 3: the middle estimate sits 0.50 log units above what was measured, and the stated range ends above it.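

In this assay, for the compounds shown here, chloro in place of hydrogen on an aromatic carbon, meta to an amino group and para to a large group, gives a number 0.70 log units lower from compound 1 to compound 3 (beyond the scatter) as the first measured step on the core of compound 1. This shows that the read-out responds to a change at this position. Nothing measured here accounts for the size of this step. The compounds shown leave open whether fluoro, a methoxy group or a carboxylic acid at this position would move the number in the same direction. They also leave open whether chloro at another place on this ring would do so.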